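Adding a chloro group to compound 1

The source may report more compounds than this note shows. Statements on the series, on what has been measured and on what is new or still open speak of the compounds shown alone.

Compound 1 `Fc1ccc(Cn2cnc3c(-c4ccco4)ncnc32)cc1`: > 10 ug/mL (a limit)
Compound 2 `Fc1ccccc1Cn1cnc2c(-c3ccco3)ncnc21`: > 10 ug/mL (a limit)

In a functional assay on Vero cells (Chlorocebus sabaeus) for inhibition (on this read-out lower numbers stand for stronger inhibition and higher numbers for weaker inhibition), compound 1 stands at > 10 ug/mL, which is a limit and not a number. The evidence so far is the limit of > 10 ug/mL in this assay, at which 2 of the 2 values shown sit. Compound 3 `Fc1ccc(Cn2cnc3c(-c4ccco4)nc(Cl)nc32)cc1` differs from compound 1 in one place: chloro in place of hydrogen on an aromatic carbon. Among the compounds with values here, the only measured step is a step that the two limits leave unreadable from compound 1 to compound 2. It changes another part of the molecule and has no readable size, so it gives no guide to this change. No firm direction can be expected, and the estimated step is a number no higher from compound 1 to compound 3 (the limit leaves the size open). Compound 3 is expected at 10 ug/mL, with an estimated range from 3 ug/mL to 30 ug/mL.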

Compound 3, half-maximal inhibitory concentration: 11.5 ug/mL
For compound 3 the middle estimate is 1.2-fold (0.06 log units) below the measured one, within the range that was stated.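

No step can be read from compound 1 to compound 3, as compound 1 has only a limit and not a number. From the compounds shown here alone, whether chloro in place of hydrogen changes inhibition at all, and in which direction, stays open.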